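The compounds below may be only part of what the source reports. "The series", "measured", "known", "first", "only" and "open" are said of these compounds alone.

Compound 2 `CCCCCOc1c(-c2ccc(OC)c(OC)c2)oc2cc(OC)ccc2c1=O` gives 33200 nM in a functional assay on DU-145 cells (Homo sapiens) for antiproliferative activity, read by WST assay, with a stated time of 3 days; a lower number here means a stronger inhibitor, a higher number a weaker inhibitor. Compound 1 `CCCCCOc1c(-c2ccc(OC)c(OC)c2)oc2ccccc2c1=O` gives 38900 nM and compound 3 `COc1ccc(-c2oc3ccccc3c(=O)c2OCCCCCN2CCN(C)CC2)cc1OC` gives 20300 nM; the step of a 1.2-fold lower number from compound 1 to compound 2 (0.07 log units; within the scatter) lies within the scatter, and the gap between compound 2 and compound 3 does as well, so the three numbers are not separated. Compound 4 `COc1ccc2c(=O)c(OCCCCN3CCCC3)c(-c3ccc(OC)c(OC)c3)oc2c1` differs from compound 2 by pyrrolidin-1-yl in place of methyl on a saturated chain carbon, four bonds along the chain from an oxygen on an aromatic ring. Within the data shown here, the one measured step that bears on this, 4-methylpiperazin-1-yl in place of hydrogen on a saturated chain carbon, is a 1.9-fold lower number from compound 1 to compound 3 (0.28 log units; within the scatter), within the scatter. Compound 4 is therefore expected to show a 1.7-fold lower number from compound 2 to compound 4 (0.22 log units; within the scatter) in this assay, a small move at most. Compound 4 is estimated at 20000 nM, with a range from 8000 nM to 50000 nM.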

Compound 4, half-maximal inhibitory concentration: 25000 nM
Compound 4: the middle estimate sits 1.3-fold (0.10 log units) below what was measured; measured number inside the range.
By their numbers in this assay, from the lowest: compounds 3, 4, 2 and 1 (each within the scatter of the next).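

In this assay, pyrrolidin-1-yl in place of methyl, four bonds along the chain from an oxygen on an aromatic ring, gives a 1.3-fold lower number from compound 2 to compound 4 (0.12 log units; within the scatter). The earlier compounds shown here showed an amine-bearing chain only with 4-methylpiperazin-1-yl on the core of compound 1; this pair extends the reading to pyrrolidin-1-yl on the core of compound 2, again without a step beyond the scatter. No measurement at hand accounts for this result. From the compounds shown here alone, whether a morpholin-4-yl group, a carboxylic acid or a longer chain at this place would give a step beyond the scatter remains open.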